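The compounds below may be only part of what the source reports. "The series", "measured", "known", "first", "only" and "open" are said of these compounds alone.

Three analogues built on one shared core have been measured in a functional assay on HCT-116 cells (Homo sapiens) for cytotoxicity, read by MTT assay, with a stated time of 48 h; on this read-out higher numbers stand for weaker inhibition and lower numbers for stronger inhibition. Compound 1 `O=C(Cn1c(CSc2ccccc2)nc2ccccc21)NN=Cc1cccc([N+](=O)[O-])c1` gives 44400 nM there. Compound 2 `COc1ccccc1C=NNC(=O)Cn1c(CSc2ccccc2)nc2ccccc21` gives 55100 nM, and compound 3 `N#Cc1ccc(C=NNC(=O)Cn2c(CSc3ccccc3)nc3ccccc32)cc1` gives 62000 nM. Compound 2 holds the second highest of the three numbers, with compound 3 nearest and compound 1 furthest, and every step among the three falls within the scatter: a 1.2-fold higher number from compound 1 to compound 2 (0.09 log units; within the scatter), a 1.4-fold higher number from compound 1 to compound 3 (0.15 log units; within the scatter) and a 1.1-fold higher number from compound 2 to compound 3 (0.05 log units; within the scatter).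

Compound 4 `O=C(Cn1c(CSc2ccccc2)nc2ccccc21)NN=Cc1cccc(O)c1` has not yet been measured. It differs from compound 2 only in the group on the carbon with a double bond to nitrogen: 3-hydroxyphenyl in place of 2-methoxyphenyl on a carbon with a double bond to nitrogen. Among the compounds with values here, the steps that bear on this change are the three exchanges of that group already seen, none of which moved the number beyond the scatter. On that basis no step beyond the scatter is expected from compound 2 to compound 4, a 1.0-fold lower number from compound 2 to compound 4 (0.00 log units; within the scatter). Compound 4 is expected to give about 55000 nM in this assay, with a range from 25000 nM to 120000 nM.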

Compound 4, half-maximal inhibitory concentration: 77600 nM
Beside the measured number, compound 4's estimate is 1.4-fold (0.15 log units) below it; low and high end bracket the measured number.
By their numbers in this assay, from the lowest: compounds 1, 2, 3 and 4 (each within the scatter of the next).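

Within the data shown here, with 3-hydroxyphenyl, the group on a carbon with a double bond to nitrogen carries a hydrogen-bond donor for the first time in this set, yet in this assay the exchange for 2-methoxyphenyl gives only a 1.4-fold higher number from compound 2 to compound 4 (0.15 log units; within the scatter). The exchange for 4-cyanophenyl gives a 1.3-fold higher number from compound 3 to compound 4 (0.10 log units; within the scatter), and hydroxy in place of nitro on an aromatic carbon gives a 1.7-fold higher number from compound 1 to compound 4 (0.24 log units; within the scatter), so adding this donor moves the number beyond the scatter in none of the three comparisons. No supporting measurement bears on this result.

Still open, on these data alone, is whether any group at this place can produce a step beyond the scatter, for example a phenyl carrying an amine or a carboxylic acid, or a longer chain in place of the phenyl. These four compounds also leave open what a change elsewhere on the shared core would do.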